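The source may report more compounds than this note shows. Statements on the series, on what has been measured and on what is new or still open speak of the compounds shown alone.

Compound 2 `COc1ccc(-c2nn3cc(-c4cccc(N)c4)nc3s2)cc1` carries a free amino group on the ring that hangs from the shared core. In a functional assay on HeLa cells (Homo sapiens) for inhibition, read by cell counting, with a stated time of 4 days (a higher number here means a weaker inhibitor, a lower number a stronger inhibitor), compound 2 gives only a limit of the measurement, >= 250000 nM, and no number. That limit, described in the limit of >= 250000 nM in this assay, at which 1 of the 2 values shown sits, is where compound 2 stands among the values shown. Compound 1 `C=C(Br)C(=O)Nc1cccc(-c2cn3nc(Cc4cccc(OC)c4)sc3n2)c1` has the same reactive (1-bromoethenyl)carbonyl amide on its outer ring, though its methoxyphenyl group is joined to the core through a single-carbon link; in this assay compound 1 gives 2500 nM. Compound 3 `C=C(Br)C(=O)Nc1cccc(-c2cn3nc(-c4ccc(OC)cc4)sc3n2)c1` differs from compound 2 by (1-bromoethenyl)carbonyl in place of hydrogen on a nitrogen on an aromatic ring. For the measured compounds named here, no measured step covers this change, so its size is not known from the data; since compound 1 with the same amide reaches 2500 nM, the step from compound 2 to compound 3 is expected to be large, toward stronger inhibition, an at least 50-fold lower number from compound 2 to compound 3 (1.69 log units; beyond the scatter). Compound 3 is therefore estimated at 5000 nM, between 1000 nM and 40000 nM.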

Compound 3, half-maximal inhibitory concentration: 2300 nM
Compound 3: middle estimate off by 2.2-fold (0.34 log units), on the high side; low and high end bracket the measured number.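

Swapping hydrogen for (1-bromoethenyl)carbonyl on the nitrogen now has a measured size in this assay, and it is large: an at least 100-fold lower number from compound 2 to compound 3 (2.03 log units; beyond the scatter). Compound 2 gives only a limit of the assay and no number: the limit of >= 250000 nM in this assay, at which 1 of the 3 values shown sits. With the (1-bromoethenyl)carbonyl amide in place, 4-methoxyphenyl in place of 3-methoxybenzyl on an aromatic carbon barely registers, a 1.1-fold lower number from compound 1 to compound 3 (0.04 log units; within the scatter).

The compounds shown leave open whether the large step needs the bromine or the whole group, which a plain acetyl or propenoyl amide on the same nitrogen would help to separate. They also leave open how far the group on the shared core can stray from these two methoxy-bearing ones, for instance to a carboxylic acid or an amine on the outer ring.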